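This account rests on a few compounds, and the source may have more. Where it says the series, first, only, none or still open, it means among the compounds named here.

Measured compounds: compound 1 `COc1ccc(-c2[nH]c3ccccc3c2/C=C(\C#N)S(=O)(=O)c2ccccc2)cc1`, 803 nM in a functional assay on A549 cells (Homo sapiens) for inhibition, read by sulforhodamine B assay, with a stated time of 48 h; a higher number here means a weaker inhibitor of growth, a lower number a stronger inhibitor of growth; compound 2 `CCOC(=O)C(=Cc1c(-c2ccccc2)[nH]c2ccccc12)C(=O)OCC`, 6400 nM; compound 3 `COc1ccc(-c2[nH]c3ccc(OC)cc3c2/C=C(\C#N)S(=O)(=O)c2ccccc2)cc1`, 2800 nM.

Compound 3 stands second highest of the three numbers, with compound 2 as its nearest neighbour and compound 1 furthest from it, lower. Compound 4 `COc1ccc2[nH]c(-c3ccccc3)c(/C=C(\C#N)S(=O)(=O)c3ccccc3)c2c1` differs from compound 3 by hydrogen in place of methoxy on an aromatic carbon. Within the data shown here, the only single-place step measured, a 3.5-fold higher number from compound 1 to compound 3 (0.54 log units; beyond the scatter), concerns a methoxy on the shared core rather than the one that leaves here, so it does not bear directly on this change, and no measured pair isolates the methoxy that sits para to a large group. A step no larger than the scatter is therefore expected, estimated as a 1.1-fold higher number from compound 3 to compound 4 (0.03 log units; within the scatter). Compound 4 is expected to give 3000 nM, within 1200 nM to 8000 nM.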

Compound 4, concentration for 50% growth inhibition: 6000 nM
The estimate for compound 4 lay 2.0-fold (0.30 log units) below the measured number; the range from low to high includes it.
By their numbers in this assay, from the lowest: compound 1; then compound 3; then compounds 4 and 2 (each within the scatter of the next).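

In this assay, the change from 4-methoxyphenyl to phenyl gives a step beyond the scatter (a 2.1-fold higher number from compound 3 to compound 4 (0.33 log units; beyond the scatter)). The methoxy at this place therefore goes with a lower number, whereas the methoxy on the shared core goes with a higher one (a 3.5-fold higher number from compound 1 to compound 3 (0.54 log units; beyond the scatter)), so the two methoxy groups of compound 3 act in opposite directions on the number. No measurement given here explains this difference. On these data alone, whether the step holds without the core methoxy remains open, as does how a hydroxyl, an amine or a fluorine would read at this place.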